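Fluoro for methoxy on the pendant aryl ring

The source may hold more compounds than are shown below. What is called first, only, known or untested is meant among the compounds shown, and "the series" means these compounds.

Compound 2 `COc1ccc(-c2cn3ccnc3c(-c3ccc4ncn(C5CCCCC5)c4c3)n2)cc1` stands highest of the two compounds measured in a functional assay on SNB-19 cells (Homo sapiens) for inhibition, read by sulforhodamine B assay, with a stated time of 48 h, tested at 10 uM (a higher number here means more inhibition at the concentration tested (going by the name of the read-out), a lower number less inhibition), where compound 2 gives 68.4%. Its nearest neighbour, compound 1 `Brc1cn2ccnc2c(-c2ccc3ncn(C4CCCCC4)c3c2)n1`, gives 8.09% in this assay. Compound 3 `Fc1ccc(-c2cn3ccnc3c(-c3ccc4ncn(C5CCCCC5)c4c3)n2)cc1` differs from compound 2 by fluoro in place of methoxy on an aromatic carbon. Among the compounds with values here, the only measured step, a number 60.3 percentage points higher from compound 1 to compound 2 (beyond the scatter), concerns a different change and bears on this one only in showing that the aryl group carries the activity. With the aryl kept, a moderate drop is expected, so compound 3 is estimated at 50%, range 25% to 75%, a step of a number 18.4 percentage points lower from compound 2 to compound 3 (beyond the scatter).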

Compound 3, a percentage reported as inhibition, at one concentration (the size of the read-out at that concentration, not a potency): 14.2%
Compound 3: middle estimate off by 35.8 percentage points, on the high side, outside the stated range (below it).
By their numbers in this assay, from the lowest: compounds 1 and 3 (each within the scatter of the next); then compound 2.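

On the pendant aryl ring, the group para to a large group governs the read-out: in this assay, fluoro in place of methoxy gives a number 54.2 percentage points lower from compound 2 to compound 3 (beyond the scatter) and removes most of the gain seen with the 4-methoxyphenyl group. An aryl group alone is therefore not enough, as 4-fluorophenyl in place of bromo gives a number 6.1 percentage points higher from compound 1 to compound 3 (within the scatter) and only the methoxy compound stands apart in this set. No evidence bearing on the cause is available.

Open, as far as these compounds go, is whether ethoxy, hydroxy or a dimethylamino group at this place would retain the level of compound 2. Also open, from the compounds shown here alone, is whether methoxy elsewhere on the ring would do so.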